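The source may report more compounds than this note shows. Statements on the series, on what has been measured and on what is new or still open speak of the compounds shown alone.

Compound 1 `O=C1/C(=C/c2ccccc2)CCC/C1=C\c1ccc(O)cc1`: 53%
Compound 2 `O=C(C1=C(O)/C(=C/c2ccc(O)cc2)CCC1)c1ccccc1`: 34.9%
Compound 3 `O=C(/C=C(O)/C=C/c1ccco1)c1cc(O)ccc1O`: 98.4%

Of the compounds shown here, three have been measured in an assay on isolated protein for inhibition of Alpha glucosidase (Homo sapiens), with stated times of 5 min and 15 min, tested at 50 uM; a lower number here means less inhibition, a higher number more inhibition at the concentration tested (going by the name of the read-out). Compound 1 sits second highest of the three numbers. Its nearest neighbour on the numbers is compound 2, whose reading is lower than that of compound 1 by a margin beyond the usual scatter. Compound 3 stands furthest away, with a reading well above compound 1, again beyond the scatter. No pair among these three differs in only one place, so the numbers offer no isolated step from which the effect of a single change could be read.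

The unmeasured compound 4 `O=C1/C(=C/c2ccccc2)CCC/C1=C\c1ccccc1Cl` departs from compound 1 in one place: 2-chlorophenyl in place of 4-hydroxyphenyl on a double-bonded chain carbon bound to a double-bonded ring carbon. Because compound 1 gives 53% in this assay, and because compound 3, which carries several hydroxyl groups, gives 98.4%, the hydroxyl-bearing members sit at the upper end of what has been measured. A moderate downward step, a number 13 percentage points lower from compound 1 to compound 4 (beyond the scatter), is therefore expected, of a size likely beyond the scatter. Compound 4 is estimated to give 40% in this assay, within a range from 15% to 65%.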

Compound 4, a percentage reported as inhibition, at one concentration (the size of the read-out at that concentration, not a potency): 43%
Compound 4: the middle estimate sits 3 percentage points below what was measured, and the stated range covers the measured number.
By their numbers in this assay, from the lowest: compounds 2, 4 and 1 (each within the scatter of the next, the first and the last beyond it); then compound 3.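

In this assay, within the data shown here, the step with 2-chlorophenyl in place of 4-hydroxyphenyl on a double-bonded chain carbon bound to a double-bonded ring carbon gives a number 10 percentage points lower from compound 1 to compound 4 (within the scatter), the first comparison in this set that isolates a change in one place. It shows that, on the core of compound 1, this position accepts an exchange that removes the hydrogen-bond donor and acceptor of the 4-hydroxyphenyl group without taking the reading beyond the scatter, so a hydroxyl group at this place is not needed for a reading of this size at the single concentration tested. The data shown offer no measured explanation for this outcome.

Among these compounds, the single step changes the hydroxyl group, the chlorine atom and the place of the substituent on the ring together, so the share of each remains unresolved, and a single-concentration reading does not give a potency. From the compounds shown here alone, how an amine, a methoxy group or a carboxylic acid on the phenyl ring at this position would read also remains open, as does the effect of any change on the other phenyl ring of the core.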